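A Single Ring Stereocentre Inverted in a Prostacyclin Agonist Pair

The compounds below may be only part of what the source reports. "The series", "measured", "known", "first", "only" and "open" are said of these compounds alone.

Compound 1 `O=C(O)CC[C@H]1CC[C@@H]2[C@@H](/C=C/[C@@H](O)COc3ccccc3)[C@H](O)C[C@@H]2OC1` and compound 2 `O=C(O)CCC[C@@H]1CC[C@@H]2[C@@H](/C=C/[C@@H](O)COc3ccccc3)[C@H](O)C[C@@H]2OC1` share a bicyclic core carrying a phenoxy-substituted hydroxyalkenyl side chain and an acid-bearing chain. In an ADME assay on CHO cells for agonist activity at prostacyclin receptor (Homo sapiens), read by HTRF and cAMP accumulation (a lower number here means that less compound is needed, a higher number that more compound is needed for the effect), compound 1 gives > 10000 nM, which is a limit of the assay rather than a number. In this assay compound 2 likewise gives > 10000 nM, again only a limit. Thus compound 2 stands at the limit of > 10000 nM in this assay, at which 2 of the 2 values shown sit, with no measured potency to anchor it.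

Compound 3 `O=C(O)CCC[C@H]1CC[C@@H]2[C@@H](/C=C/[C@@H](O)COc3ccccc3)[C@H](O)C[C@@H]2OC1` is the next compound. It differs from compound 2 as follows: the two compounds have the same atoms and bonds and differ only in configuration as drawn: 1 of 7 stereo elements differ; a stereocentre at a saturated ring carbon is drawn R in compound 2 and S in compound 3. Among the measured compounds shown here, no measured pair in this set isolates such a configurational change, so no step size can be read from the data. A change at a stereocentre may be expected to shift potency in either direction or not beyond the scatter. Compound 3 is estimated at 2000 nM, with a range from 150 nM to 10000 nM, which would mean an expected step of an at least 5.0-fold lower number from compound 2 to compound 3 (0.69 log units; beyond the scatter).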

Compound 3, half-maximal effective concentration: > 10000 nM
Compound 3: a limit, no number; the forecaster's own chance of this, stated with the estimate: 45%; at least 5.0-fold (0.69 log units) between middle value and limit.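

In this assay compound 3 gives > 10000 nM, again a limit of the assay and not a number, so the steps to it from compound 1 and from compound 2 cannot be read. The compounds shown leave open whether the inverted ring stereocentre or the added carboxymethyl changes potency at all: the limit of > 10000 nM in this assay, at which 3 of the 3 values shown sit.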